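Replacing methyl with trifluoromethyl in compound 3

The source may hold more compounds than are shown below. What is called first, only, known or untested is meant among the compounds shown, and "the series" means these compounds.

Measured in an ADME assay on HepG2 2.2.15 cells (Homo sapiens) for cytotoxicity, read by CCK-8 assay, with a stated time of 8 days; on this read-out lower numbers stand for higher toxicity in this test and higher numbers for lower toxicity in this test:
compound 1 `COc1ccc(C(=O)Nc2c[nH]c(=O)c(-c3cccc(C)c3)c2)c(O)c1`: > 100000 nM, a limit of the assay
compound 2 `Cc1cccc(-c2cc(NC(=O)c3ccc(Cl)cc3O)c[nH]c2=O)c1`: 33100 nM
compound 3 `Cc1cccc(-c2cc(NC(=O)c3ccc(C)cc3O)c[nH]c2=O)c1`: 75000 nM

Compound 3 at 75000 nM holds the higher of the two actual numbers in this assay, and compound 2 lies lower. Compound 4 `Cc1cccc(-c2cc(NC(=O)c3ccc(C(F)(F)F)cc3O)c[nH]c2=O)c1` carries trifluoromethyl in place of methyl on an aromatic carbon, para to a large group: trifluoromethyl in place of methyl on an aromatic carbon. The closest measured change at this carbon is a 2.3-fold higher number from compound 2 to compound 3 (0.36 log units; beyond the scatter), a modest step. Also relevant are an at least 3.0-fold lower number from compound 1 to compound 2 (0.48 log units; beyond the scatter) and an at least 1.3-fold lower number from compound 1 to compound 3 (0.12 log units; that floor lies within the scatter), whose floor lies within the scatter. Going by the values given here, no measured compound carries trifluoromethyl, so chloro serves as a loose guide. A modest move to a lower number is expected, a 2.1-fold lower number from compound 3 to compound 4 (0.33 log units; beyond the scatter). Compound 4 is estimated at 35000 nM, with an expected range of 14000 nM to 85000 nM.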

Compound 4, half-maximal cytotoxic concentration: 24200 nM
For compound 4 the middle estimate is 1.4-fold (0.16 log units) above the measured one; measured number inside the range.
By their numbers in this assay, from the lowest: compounds 4 and 2 (each within the scatter of the next); then compound 3. At a limit, above all of these: compound 1.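

In this assay, trifluoromethyl in place of methyl gives a 3.1-fold lower number from compound 3 to compound 4 (0.49 log units; beyond the scatter), and chloro and trifluoromethyl stay within the scatter of each other, with a 1.4-fold lower number from compound 2 to compound 4 (0.14 log units; within the scatter). Both groups therefore lie on the same side of methyl at this carbon, which the chloro and methyl pair alone could not show. The step of an at least 4.1-fold lower number from compound 1 to compound 4 (0.61 log units; beyond the scatter) starts from the limit of compound 1: the limit of > 100000 nM in this assay, at which 1 of the 4 values shown sits.

On these data alone, whether an amine, a nitrile or a carboxylic acid at this carbon would read closer to methyl or to chloro and trifluoromethyl stays open. The compounds shown vary this one carbon only, so the same change elsewhere on the core remains untested.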